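The source may hold more compounds than are shown below. What is called first, only, known or untested is meant among the compounds shown, and "the series" means these compounds.

In an ADME assay on GES1 cells (Homo sapiens) for inhibition, read by MTT assay, with a stated time of 72 h (on this read-out higher numbers stand for weaker inhibition and lower numbers for stronger inhibition), compound 1 `Cc1cc(Nc2cc(-c3cccs3)[nH]n2)n2nc(SCc3ccc(Br)cc3)nc2n1` gives 38700 nM and lies within the scatter of compound 2 `Cc1cc(Nc2ccn(Cc3cccc4ccccc34)n2)n2nc(SCc3ccc(Br)cc3)nc2n1` at 30000 nM and of compound 3 `Cc1cc(Nc2ccn(Cc3ccccc3)n2)n2nc(SCc3ccc(Br)cc3)nc2n1` at 44400 nM without a clear place among them. The move to compound 4 `Cc1cc(Nc2cc(-c3ccccc3)[nH]n2)n2nc(SCc3ccc(Br)cc3)nc2n1` is phenyl in place of thiophen-2-yl on an aromatic carbon and amounts to phenyl in place of thiophen-2-yl on an aromatic carbon. Among the compounds with values here, no measured step covers this place. Within the data shown here, the only measured step is a 1.5-fold higher number from compound 2 to compound 3 (0.17 log units; within the scatter) with phenyl in place of naphthalen-1-yl on a saturated chain carbon bound to an aromatic nitrogen, so it bears on the present change only indirectly. That step lies within the scatter, and no direction can be drawn from it. No step beyond the scatter is therefore expected in this assay for this change. The estimate is a 1.0-fold lower number from compound 1 to compound 4 (0.01 log units; within the scatter) as the expected step. For compound 4 the expected value is 38000 nM with an estimated range from 20000 nM to 70000 nM in this read-out.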

Compound 4, half-maximal inhibitory concentration: 39300 nM
For compound 4 the middle estimate is 1.0-fold (0.01 log units) below the measured one; the range from low to high includes it.
By their numbers in this assay, from the lowest: compounds 2, 1, 4 and 3 (each within the scatter of the next).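

In this assay, phenyl in place of thiophen-2-yl on an aromatic carbon next to the ring nitrogen gives a 1.0-fold higher number from compound 1 to compound 4 (0.01 log units; within the scatter), the first step shown at this position. At this place, a five-membered aromatic ring with a sulfur atom and a six-membered aromatic ring of carbon only cannot be told apart in this read-out, so the earlier finding of no readable step, from a change on a saturated chain carbon, now has a counterpart on the aromatic carbon. No supporting data bear on this result.

Going by these compounds, whether an amine, a carboxylic acid or a longer alkyl chain at this place would also stay within the scatter remains open. Also open, on these data alone, is whether a hydroxyl or methoxy group on the phenyl would separate a compound from this group.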